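The source may hold more compounds than are shown below. What is called first, only, known or untested is meant among the compounds shown, and "the series" means these compounds.

Compound 1 `Oc1ccc(-c2cc(-c3ccc(C(F)(F)F)cc3)cc(-c3cccc(O)c3)n2)cc1` and compound 2 `Oc1ccc(-c2cc(-c3ccc(C(F)(F)F)cc3)cc(-c3ccc(O)cc3)n2)cc1` share one core, while compound 3 `Oc1cccc(-c2cc(-c3ccccc3OC(F)(F)F)cc(-c3cccc(O)c3)n2)c1` and compound 4 `Oc1ccc(-c2cc(-c3ccccc3OC(F)(F)F)cc(-c3cccc(O)c3)n2)cc1` share another; the difference between the two cores is not broken down here. In a functional assay on DU-145 cells (Homo sapiens) for inhibition (a lower number here means a stronger inhibitor, a higher number a weaker inhibitor), compound 1 gives > 50000 nM, which is a limit of the assay rather than a number. Compound 2 likewise gives only a limit, > 50000 nM. The step that the two limits leave unreadable from compound 1 to compound 2 is therefore unreadable, a consequence of the limit of > 50000 nM in this assay, at which 2 of the 3 values shown sit. Compound 3 gives 5420 nM in this assay. The change from compound 3 to compound 4 is 4-hydroxyphenyl in place of 3-hydroxyphenyl on an aromatic carbon, the same kind of change as 4-hydroxyphenyl in place of 3-hydroxyphenyl on an aromatic carbon, though the surroundings differ: in the second pair the place is meta to a 4-(trifluoromethyl)phenyl group and meta to a 4-hydroxyphenyl group. With the measured instance unreadable, a step of a 1.5-fold higher number from compound 3 to compound 4 (0.17 log units; within the scatter) is expected in this assay, resting only on the measured value of compound 3, 5420 nM. Compound 4 is estimated at 8000 nM, between 2500 nM and 30000 nM.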

Compound 4, half-maximal inhibitory concentration: 7760 nM
The estimate for compound 4 lay 1.0-fold (0.01 log units) above the measured number; low and high end bracket the measured number.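

In this assay, putting 4-hydroxyphenyl in place of 3-hydroxyphenyl gives a 1.4-fold higher number from compound 3 to compound 4 (0.16 log units; within the scatter), so the change makes no readable difference in the core of compound 3. The same change in the core of compound 1 cannot be read, since compound 1 and compound 2 each give only a limit of the assay: the limit of > 50000 nM in this assay, at which 2 of the 4 values shown sit. The result therefore rests on one core and does not show that the change would behave alike in the other.

Open, as far as these compounds go, is how an amine or a carboxylic acid in place of the hydroxyl would read in this assay. Also open, from the compounds shown here alone, is whether a phenyl ring without any hydroxyl would hold the number of compound 3.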